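A few compounds are considered here, and "the series" means these few. Any claim that something is new, unique, unknown or untested is made for them only; others in the source may bear on it.

Measured values in a functional assay on NCI-H460 cells (Homo sapiens) for cytotoxicity, read by MTT assay, with a stated time of 72 h; a higher number here means a weaker inhibitor, a lower number a stronger inhibitor:
compound 1 `CN(C)CCn1cnnc1-c1cc(Oc2ccc(NC(=O)N/N=C/c3cc(Br)c(O)c(Br)c3)cc2F)ccn1`, 3760 nM
compound 2 `CN(C)CCn1cnnc1-c1cc(Oc2ccc(NC(=O)N/N=C/c3c[nH]c4ccccc34)cc2F)ccn1`, 1630 nM
compound 3 `COc1ccc(/C=N/NC(=O)Nc2ccc(Oc3ccnc(-c4nncn4CCN(C)C)c3)c(F)c2)c(OC)c1OC`, 1790 nM

Compound 3 holds the second highest of the three numbers. Its nearest neighbour is compound 2, the step of a 1.1-fold higher number from compound 2 to compound 3 (0.04 log units; within the scatter) lying within the scatter; its furthest is compound 1, with a 2.1-fold lower number from compound 1 to compound 3 (0.32 log units; beyond the scatter) beyond the scatter. The aryl on the carbon with a double bond to nitrogen is the only site varied across the set.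

Compound 4 `CN(C)CCn1cnnc1-c1cc(Oc2ccc(NC(=O)N/N=C/c3ccc(O)cc3O)cc2F)ccn1` differs from compound 3 at that same site: 2,4-dihydroxyphenyl in place of 2,3,4-trimethoxyphenyl on a carbon with a double bond to nitrogen.

Within the data shown here, two measured steps bear on this. Among the measured compounds shown here, compound 1, the only compound carrying a hydroxyl on that aryl, gave the highest number, and replacing its aryl lowered the number modestly in both a 2.3-fold lower number from compound 1 to compound 2 (0.36 log units; beyond the scatter) and a 2.1-fold lower number from compound 1 to compound 3 (0.32 log units; beyond the scatter). Going to compound 4 brings hydroxyls back, though without bromines, so no exact match exists. A small rise in number, possibly within the scatter, is expected. For compound 4 the estimate is 2600 nM, with the step of a 1.5-fold higher number from compound 3 to compound 4 (0.16 log units; within the scatter) and a range from 1100 nM to 6000 nM.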

Compound 4, half-maximal inhibitory concentration: 11300 nM
The estimate for compound 4 lay 4.3-fold (0.64 log units) below the measured number; measured number outside the range, above it.
By their numbers in this assay, from the lowest: compounds 2 and 3 (each within the scatter of the next); then compound 1; then compound 4.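

In this assay, among these compounds, the aryl on the carbon with a double bond to nitrogen proves able to move the number further than the earlier compounds showed, with 2,4-dihydroxyphenyl giving larger steps (a 6.3-fold higher number from compound 3 to compound 4 (0.80 log units; beyond the scatter); a 6.9-fold higher number from compound 2 to compound 4 (0.84 log units; beyond the scatter)) than any seen among compounds 1, 2 and 3. It also stands above the other hydroxyl-bearing aryl (a 3.0-fold higher number from compound 1 to compound 4 (0.48 log units; beyond the scatter)), so among these four compounds the two aryls with hydroxyls, in compound 1 and compound 4, give the two highest numbers, with no compound against that pattern. No measurement on these compounds accounts for the size of this rise.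

Still open, as far as these compounds go, is whether the rise follows the free hydroxyls themselves, which a phenyl carrying methoxy groups or amines in their place would test. From the compounds shown here alone, the shared core stays constant throughout, so whether this order holds on another core also remains open.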